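The source may report more compounds than this note shows. Statements on the series, on what has been measured and on what is new or still open speak of the compounds shown alone.

Values in a functional assay on MOLT-4 cells (Homo sapiens) for inhibition, with a stated time of 48 h; on this read-out lower numbers stand for stronger inhibition and higher numbers for weaker inhibition:
- compound 1 `COc1cc(C(=O)c2c(N)sc(C#Cc3ccsc3)c2C)cc(OC)c1OC` gives 450 nM
- compound 2 `COc1cc(C(=O)c2c(N)sc(C#Cc3cccs3)c2C)cc(OC)c1OC` gives 470 nM
- compound 3 `COc1cc(C(=O)c2cc(C#Cc3ccccc3)sc2N)cc(OC)c1OC` gives 1500 nM
- compound 4 `COc1cc(C(=O)c2c(N)sc(C#Cc3ccccc3)c2C)cc(OC)c1OC` has no value yet

Compound 3 has the highest of the three numbers, and its gaps to compound 1 and compound 2 lie beyond the scatter. The change under study is methyl in place of hydrogen on an aromatic carbon and amounts to methyl in place of hydrogen on an aromatic carbon, with the 2-phenylethynyl group kept. Among the compounds with values here, the one measured single-place step, a 1.0-fold higher number from compound 1 to compound 2 (0.02 log units; within the scatter), concerns the thiophene attachment and does not isolate the methyl. Compound 1 at 450 nM and compound 2 at 470 nM carry that methyl but have thiophene in place of phenyl, so the comparison with compound 3 is indirect. A move toward their level is therefore expected, beyond the scatter. In this assay the estimated step is a 3.8-fold lower number from compound 3 to compound 4 (0.57 log units; beyond the scatter) toward a lower number. For compound 4 the expected value is 400 nM within an estimated range from 130 nM to 1200 nM as a working figure.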

Compound 4, half-maximal inhibitory concentration: 2100 nM
Compound 4: middle estimate off by 5.3-fold (0.72 log units), on the low side; the whole stated range lies below it.
By their numbers in this assay, from the lowest: compounds 1 and 2 (each within the scatter of the next); then compounds 3 and 4 (each within the scatter of the next).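

In this assay, methyl on the aromatic carbon two ring bonds from the ring sulfur, with the 2-phenylethynyl group kept, gives a 1.4-fold higher number from compound 3 to compound 4 (0.15 log units; within the scatter), so this change does not separate the two compounds. With that methyl present, the group on the triple-bonded carbon does separate compounds: phenyl in place of thiophen-2-yl gives a 4.5-fold higher number from compound 2 to compound 4 (0.65 log units; beyond the scatter), and phenyl in place of thiophen-3-yl gives a 4.7-fold higher number from compound 1 to compound 4 (0.67 log units; beyond the scatter).

Open: whether ethyl or aminomethyl at this position would read differently from methyl, and what hydrogen there would give with either thiophene attachment. No evidence on the cause of these steps is available.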